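Azetidinyl replacement on the tricyclic quinone series

The source may hold more compounds than are shown below. What is called first, only, known or untested is meant among the compounds shown, and "the series" means these compounds.

Measured so far:
compound 1 `Cc1ccc(NC2=CC(=O)c3nc4n(c3C2=O)[C@H]2OC[C@@H](O)[C@H]2OC4)cc1C` — 2690 nM
compound 2 `O=C1C(NCc2ccccc2)=CC(=O)c2c1nc1n2[C@H]2OC[C@@H](O)[C@H]2OC1` — 11000 nM

In a functional assay on HeLa cells (Homo sapiens) for inhibition, read by sulforhodamine B assay (on this read-out lower numbers stand for stronger inhibition and higher numbers for weaker inhibition), compound 1 gives the lower of the two numbers; compound 2 gives 11000 nM, a gap beyond the scatter. Compound 3 `O=C1C=C(N2CCC2)C(=O)c2c1nc1n2[C@H]2OC[C@@H](O)[C@H]2OC1` has not been measured. Compared with compound 1 it carries azetidin-1-yl in place of (3,4-dimethylphenyl)amino on a double-bonded ring carbon. Within the data shown here, no measured pair isolates this change. With the donor and the aromatic ring gone, weaker inhibition is expected, a step of a 5.6-fold higher number from compound 1 to compound 3 (0.75 log units; beyond the scatter) of moderate size. Compound 3 is therefore estimated at 15000 nM, within 4000 nM to 60000 nM.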

Compound 3, half-maximal inhibitory concentration: > 16000 nM
Compound 3 gave a limit, no number; the forecaster's own chance of this, stated with the estimate: 20%; middle value at least 1.0-fold (0.02 log units) from the limit.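

In this assay azetidin-1-yl in place of (3,4-dimethylphenyl)amino on the double-bonded ring carbon gives an at least 5.9-fold higher number from compound 1 to compound 3 (0.77 log units; beyond the scatter) as the first single-change step read at this position. The change removes the aromatic ring and the hydrogen-bond donor together, so the step does not separate them. For compound 3 the value > 16000 nM is a limit and not a number, so the step has a lower bound only: the limit of > 16000 nM in this assay, at which 1 of the 3 values shown sits.

Open, from the compounds shown here alone, is whether a dimethylamino group or a morpholin-4-yl ring at this carbon behaves like azetidin-1-yl. An unsubstituted phenylamino group would show how much of compound 1's inhibition depends on its two methyl groups.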